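The compounds below may be only part of what the source reports. "The series", "measured", "known", "first", "only" and "open" are said of these compounds alone.

Measured so far in an ADME assay on the whole organism (strain FVB) for pharmacokinetics, with Mus musculus as the target, read by LC-MS, at a dose of 30 mg/kg by the oral route; on this read-out higher numbers stand for higher exposure at the dose given and lower numbers for lower exposure:
- compound 1, `CC(C)(CN)Oc1ccc([C@H]2CC[C@]3(CC2)OOC2(O3)C3CC4CC(C3)CC2C4)cc1`, gives 529 nM
- compound 2, `O[C@H]1CC[C@H](NCCCOc2ccc([C@H]3CC[C@]4(CC3)OOC3(O4)C4CC5CC(C4)CC3C5)cc2)CC1`, gives 721 nM

Among the measured compounds shown here, compound 2 holds the higher of the two numbers, but only narrowly: the one step available, a 1.4-fold higher number from compound 1 to compound 2 (0.13 log units; within the scatter), lies within the scatter, so the two values cannot be ordered with confidence.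

Compound 3, `CC1(C)CC(O)(COc2ccc([C@H]3CC[C@]4(CC3)OOC3(O4)C4CC5CC(C4)CC3C5)cc2)CC(C)(C)N1`, has not yet been measured. It differs from compound 2 by 4-hydroxy-2,2,6,6-tetramethylpiperidin-4-yl in place of 2-((4-hydroxycyclohexyl)amino)ethyl on a saturated chain carbon bound to an oxygen on an aromatic ring. For the measured compounds named here, the only measured step that bears on this change is the one from compound 1 to compound 2, which also reworked the group on the oxygen of the aromatic ring and gave a 1.4-fold higher number from compound 1 to compound 2 (0.13 log units; within the scatter), a change too small to count. Going by the values given here, with the shared core left untouched and the single precedent flat, no step beyond the scatter is expected in this assay. Compound 3 is therefore estimated at 600 nM, between 250 nM and 1500 nM, which means an expected step of a 1.2-fold lower number from compound 2 to compound 3 (0.08 log units; within the scatter).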

Compound 3, maximal plasma concentration: 1000 nM
Compound 3: middle estimate off by 1.7-fold (0.22 log units), on the low side, and the stated range covers the measured number.
By their numbers in this assay, from the lowest: compounds 1, 2 and 3 (each within the scatter of the next).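

In this assay, 4-hydroxy-2,2,6,6-tetramethylpiperidin-4-yl in place of 2-((4-hydroxycyclohexyl)amino)ethyl gives a 1.4-fold higher number from compound 2 to compound 3 (0.14 log units; within the scatter), so this position accepts a six-membered ring with 1 hetero atom in place of one of carbon only without a step beyond the scatter. The wider change, (4-hydroxy-2,2,6,6-tetramethylpiperidin-4-yl)methyl in place of 1-(aminomethyl)-1-methylethyl on an oxygen on an aromatic ring, gives a 1.9-fold higher number from compound 1 to compound 3 (0.28 log units; within the scatter), and it too stays within the scatter, so the three groups on this oxygen cannot be ordered. Nothing available here accounts for these numbers.

As far as these compounds go, whether a carboxylic acid or an amide in place of the amine would give a step beyond the scatter remains open. So does what a longer chain between the oxygen and the amine would give.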